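Aryl swaps on the shared core: compound 3 to compound 4

This account rests on a few compounds, and the source may have more. Where it says the series, first, only, none or still open, it means among the compounds named here.

- compound 1 `NC(=O)[C@@H]1[C@H](Nc2nc(Nc3cccc(C(=O)N4CCCC4)c3)ncc2-c2ccoc2)[C@H]2C=C[C@@H]1C2` gives 40 nM
- compound 2 `NC(=O)[C@@H]1[C@H](Nc2nc(Nc3cccc(C(=O)N4CCCC4)c3)ncc2-c2ccsc2)[C@H]2C=C[C@@H]1C2` gives 110 nM
- compound 3 `NC(=O)[C@@H]1[C@H](Nc2nc(Nc3cccc(C(=O)N4CCCC4)c3)ncc2-c2ccnc(F)c2)[C@H]2C=C[C@@H]1C2` gives 100 nM

In a functional assay on THP-1 cells (Homo sapiens) for inhibition, read by ELISA, with stated times of 1 h and 18 h (a higher number here means a weaker inhibitor, a lower number a stronger inhibitor), the two higher numbers of the three cannot be separated, showing a 1.1-fold lower number from compound 2 to compound 3 (0.04 log units; within the scatter) and compound 3 thus sits level with compound 2. The lowest number is clearly apart, with a 2.5-fold higher number from compound 1 to compound 3 (0.40 log units; beyond the scatter) as the measured gap.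

Compound 4 `N#Cc1cccc(-c2cnc(Nc3cccc(C(=O)N4CCCC4)c3)nc2N[C@H]2[C@@H](C(N)=O)[C@@H]3C=C[C@H]2C3)c1` carries 3-cyanophenyl in place of 2-fluoropyridin-4-yl on an aromatic carbon of the six-membered aromatic ring with 2 nitrogen: 3-cyanophenyl in place of 2-fluoropyridin-4-yl on an aromatic carbon is the full change.

All three measured steps swap this same group. Two are modest, a 2.8-fold higher number from compound 1 to compound 2 (0.44 log units; beyond the scatter) and a 2.5-fold higher number from compound 1 to compound 3 (0.40 log units; beyond the scatter), and the third, a 1.1-fold lower number from compound 2 to compound 3 (0.04 log units; within the scatter), lies within the scatter. None involves a nitrile, so direction is poorly supported. In this assay a small rise or no step beyond the scatter is expected. An estimated 1.3-fold higher number from compound 3 to compound 4 (0.11 log units; within the scatter) is the expected outcome. Compound 4 is expected at 130 nM (estimated range 45 nM to 380 nM).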

Compound 4, half-maximal inhibitory concentration: 280 nM
Beside the measured number, compound 4's estimate is 2.2-fold (0.33 log units) below it; measured number inside the range.
By their numbers in this assay, from the lowest: compound 1; then compounds 3 and 2 (each within the scatter of the next); then compound 4.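

In this assay, compound 4 is the weakest inhibitor of the four, with 3-cyanophenyl set clearly apart from each earlier group (a 2.8-fold higher number from compound 3 to compound 4 (0.45 log units; beyond the scatter); a 2.5-fold higher number from compound 2 to compound 4 (0.41 log units; beyond the scatter); a 7.0-fold higher number from compound 1 to compound 4 (0.85 log units; beyond the scatter)). The step from compound 3 joins two six-membered aromatic rings, so this position separates groups even at the same ring size, whereas the earlier step between compound 2 and compound 3 did not rise beyond the scatter. The span across this position also widens, with the largest step now running from the furan-3-yl group of compound 1 to the 3-cyanophenyl group.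

Whether the nitrile or the carbon-only ring accounts for the step stays open, and a plain phenyl or a phenyl bearing an amine would help separate the two. No measurement shown here bears on the origin of these steps.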